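Compound 2 to compound 3: 2-hydroxyethyl replaced by hydroxy

A few compounds are considered here, and "the series" means these few. Any claim that something is new, unique, unknown or untested is made for them only; others in the source may bear on it.

In an ADME assay on Vero cells (Chlorocebus sabaeus) for cytotoxicity (on this read-out lower numbers stand for higher toxicity in this test and higher numbers for lower toxicity in this test), compound 1 (`Nc1ncc(F)c2c1ncn2[C@@H]1C[C@H](CO)[C@@H](O)[C@H]1O`) gives 159000 nM and compound 2 (`Nc1ncc(F)c2c1ncn2[C@@H]1C[C@H](CCO)[C@@H](O)[C@H]1O`) gives 128000 nM. Among the compounds with values here, compound 2 therefore stands within the scatter of compound 1, the only other measured member of the series, and the two cannot be told apart on this read-out.

The next change leads to compound 3 (`Nc1ncc(F)c2c1ncn2[C@@H]1C[C@H](O)[C@@H](O)[C@H]1O`), with hydroxy in place of 2-hydroxyethyl on a saturated ring carbon.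

Within the data shown here, one measured step bears on this change: a 1.2-fold lower number from compound 1 to compound 2 (0.09 log units; within the scatter). It concerns the same side chain, and its size lies within the scatter. Among the measured compounds shown here, no measured compound carries hydroxy directly at this ring carbon, so the new compound lies outside the chain variation seen so far and the expectation is loose. No step beyond the scatter is expected in this assay, and no direction is favoured. The estimate corresponds to a 1.2-fold higher number from compound 2 to compound 3 (0.07 log units; within the scatter), an expected step that stays within the scatter. For compound 3 the expected value is 150000 nM, with an estimated range of 70000 nM to 320000 nM.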

Compound 3, half-maximal cytotoxic concentration: > 300000 nM
Compound 3: a limit, no number (the forecaster's own chance of this, stated with the estimate: 30%); at least 2.0-fold (0.30 log units) between middle value and limit.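

Compound 3 reads as a limit of the assay, not a number, in this assay: the limit of > 300000 nM in this assay, at which 1 of the 3 values shown sits.

Within the data shown here, putting hydroxy on this saturated ring carbon in place of 2-hydroxyethyl gives an at least 2.3-fold higher number from compound 2 to compound 3 (0.36 log units; beyond the scatter), the only step at this position that clears the scatter, whereas the exchange between hydroxymethyl and 2-hydroxyethyl did not. Against hydroxymethyl the picture is weaker: the same position gives an at least 1.8-fold higher number from compound 1 to compound 3 (0.27 log units; that floor lies within the scatter), so compound 3 and compound 1 cannot yet be put in order, and only compound 2 is separated from compound 3 on this read-out.

On these data alone, how far compound 3 lies past its limit remains unknown, so both steps carry only a floor and no size. Also open, as far as these compounds go, is whether the shift follows from the loss of the carbon chain or from hydroxy itself, a question that an amine or a methoxy group on the same ring carbon, or a longer chain such as 3-hydroxypropyl, would bear on.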